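Working notes: replacing the carboxymethoxy group of compound 3

A few compounds are considered here, and "the series" means these few. Any claim that something is new, unique, unknown or untested is made for them only; others in the source may bear on it.

Within the data shown here, compound 3 `Cc1nc(-c2ccc(C(F)(F)F)cc2)sc1CNc1ccc(OCC(=O)O)cc1` gives 288 nM in a functional assay on CHO cells for agonist activity at Free fatty acid receptor 1 (Homo sapiens) (on this read-out lower numbers stand for an effect already at smaller amounts and higher numbers for an effect only at larger amounts of compound), and is the only compound of the three with a plain number. Compound 1 `O=C(O)c1ccc(NCc2cccc(Oc3ccccc3)c2)cc1` shows < 10000 nM in this assay, which is a limit rather than a number. Compound 2 `Cc1nc(-c2ccc(C(F)(F)F)cc2)sc1CNc1ccc(CCCC(=O)O)cc1` likewise shows < 10000 nM, again a limit. Among the measured compounds shown here, the one recorded step, a step that the limit leaves unreadable from compound 2 to compound 3, therefore cannot be read in size, and this is the general situation described by the limit of < 10000 nM in this assay, at which 2 of the 3 values shown sit. For the measured compounds named here, compound 4 `Cc1nc(-c2ccc(C(F)(F)F)cc2)sc1CNc1ccc(CCC(=O)NC(C)C)cc1` differs from compound 3 by 2-(isopropylcarbamoyl)ethyl in place of carboxymethoxy on an aromatic carbon, a change no measured step covers. With no readable precedent, a weakening beyond the scatter is tentatively expected, as an 8.7-fold higher number from compound 3 to compound 4 (0.94 log units; beyond the scatter). Compound 4 is thus estimated at 2500 nM, with a range from 400 nM to 15000 nM.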

Compound 4, half-maximal effective concentration: 100 nM
For compound 4 the middle estimate is 25-fold (1.40 log units) above the measured one; measured number outside the range, below it.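

In this assay, 2-(isopropylcarbamoyl)ethyl in place of carboxymethoxy gives a 2.9-fold lower number from compound 3 to compound 4 (0.46 log units; beyond the scatter), so compound 4 reaches its activity with an amide and no carboxylic acid on this chain. The aromatic carbon para to a large group therefore accepts a chain of this different kind without loss. Compound 2 shows < 10000 nM, which is a limit and not a number, so the steps from it cannot be read.

The change replaces the whole chain, so the shift cannot be assigned to the amide, the isopropyl or the lost ether oxygen. On these data alone, how a primary amide or a tert-butyl amide on the same chain would read remains open.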